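Swapping methoxy for fluoro: what to expect for compound 4

This account rests on a few compounds, and the source may have more. Where it says the series, first, only, none or still open, it means among the compounds named here.

Measured in a functional assay on MCF7 cells (Homo sapiens) for antiproliferative activity, read by sulforhodamine B assay, with a stated time of 48 h; on this read-out lower numbers stand for stronger inhibition and higher numbers for weaker inhibition:
- compound 1 `CN1CCN(c2ccc(S(=O)(=O)Oc3cccc(F)c3)cc2)C1=O` gives > 100000 nM
- compound 2 `CCN1CCN(c2ccc(S(=O)(=O)Oc3ccccc3OC)cc2)C1=O` gives > 100000 nM
- compound 3 `CCN1CCN(c2ccc(S(=O)(=O)Oc3cccc(OC)c3)cc2)C1=O` gives 14000 nM

Going by the values given here, compound 3 is the only compound here with an actual number, so it cannot yet be ranked against a measured neighbour. Compound 1 and compound 2 both stand at the limit of > 100000 nM in this assay, at which 2 of the 3 values shown sit, which is a limit and not a number.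

Compound 4 `CCN1CCN(c2ccc(S(=O)(=O)Oc3cccc(F)c3)cc2)C1=O` follows from compound 3 by one change, fluoro in place of methoxy on an aromatic carbon, meta to a large group: fluoro in place of methoxy on an aromatic carbon.

Among the compounds with values here, only one measured step exists, an at least 7.1-fold lower number from compound 2 to compound 3 (0.85 log units; beyond the scatter), and it shows that a change on this same phenyl group can be sizeable. Compound 1 also carries a 3-fluorophenyl group, and its > 100000 nM is likewise a limit. Both facts lean towards weaker inhibition in this assay rather than stronger.

An estimated 2.9-fold higher number from compound 3 to compound 4 (0.46 log units; beyond the scatter) is therefore expected, though it may prove small.

For compound 4 the expected value is 40000 nM, with an estimated range from 14000 nM to 100000 nM.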

Compound 4, half-maximal inhibitory concentration: > 100000 nM
Compound 4 gave a limit, no number (the forecaster's own chance of this, stated with the estimate: 45%); middle value at least 2.5-fold (0.39 log units) away from the limit.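

In this assay, going by these compounds alone, the earlier compounds showed only that moving the methoxy group on this phenyl ring matters; the new result shows that, with methoxy kept at the same place, its replacement matters too. Fluoro in place of methoxy on this aromatic carbon gives an at least 7.1-fold higher number from compound 3 to compound 4 (0.85 log units; beyond the scatter), with the rest of the molecule unchanged. Within the data shown here, compound 4 reads > 100000 nM, which is a limit and not a number, so compound 3 remains the only compound with a measured number.

The steps to compound 4 from compound 1 and from compound 2 cannot be read because both ends of each are limits: the limit of > 100000 nM in this assay, at which 3 of the 4 values shown sit. As far as these compounds go, it remains open whether a hydroxyl, an amine or a longer chain such as ethoxy at this place would give a lower number than methoxy does.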